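Changing the sulfonyl group of a triazine amide series

A few compounds are considered here, and "the series" means these few. Any claim that something is new, unique, unknown or untested is made for them only; others in the source may bear on it.

Compound 3 `CS(=O)(=O)NC(=O)c1ccc(Nc2nc(NC3(c4ccc(Cl)cc4)CC3)nc(OCC(F)(F)F)n2)cc1` is one of a small set of compounds sharing a common core and tested in an ADME assay on microsomes from liver (Rattus norvegicus) for metabolic stability, with a stated time of 10 min; a higher number here means that more of the compound is left, a lower number that less of the compound is left. Compound 3 gives 85%. Compound 1 `CC(C)(C)NC(=O)NCCS(=O)(=O)NC(=O)c1ccc(Nc2nc(NC3(c4ccc(Cl)cc4)CC3)nc(OCC(F)(F)F)n2)cc1` gives 93%, and the step of a number 8 percentage points lower from compound 1 to compound 3 (within the scatter) lies within the usual scatter of this measurement, so the two compounds cannot be told apart. Compound 2 `O=C(NS(=O)(=O)CCNC(=O)C1CC1)c1ccc(Nc2nc(NC3(c4ccc(Cl)cc4)CC3)nc(OCC(F)(F)F)n2)cc1` gives "not active" (no number reported), an outcome without a number, so it offers no comparison.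

Compound 4 `Cc1ccccc1S(=O)(=O)NC(=O)c1ccc(Nc2nc(NC3(c4ccc(Cl)cc4)CC3)nc(OCC(F)(F)F)n2)cc1` has not been measured. The change from compound 3 to compound 4 is 2-methylphenyl in place of methyl on a sulfonyl sulfur. Among the measured compounds shown here, the only measured step that bears on it is the one from compound 1 to compound 3, which also alters the group on the sulfonyl sulfur and stayed within the scatter. On that basis the step of a number 5 percentage points lower from compound 3 to compound 4 (within the scatter) is expected to stay within the scatter as well. Compound 4 is therefore estimated to give 80% in this assay, with a likely range from 60% to 95%.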

Compound 4, percent of the compound remaining: 100%
The estimate for compound 4 lay 20 percentage points below the measured number; measured number above the stated range.
By their numbers in this assay, from the lowest: compounds 3, 1 and 4 (each within the scatter of the next, the first and the last beyond it).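

Compound 4 shows that the sulfonyl sulfur can carry 2-methylphenyl, a six-membered aromatic ring of carbon only, and not just a saturated chain or methyl. In this assay, among the compounds shown here, this change gives a number 15 percentage points higher from compound 3 to compound 4 (beyond the scatter), the first step at this position to go beyond the scatter. Replacing the 2-(((tert-butyl)carbamoyl)amino)ethyl chain with the same ring gives a number 7 percentage points higher from compound 1 to compound 4 (within the scatter), so these two very different groups cannot be told apart here, and nothing shown explains either result.

The compounds shown leave open whether the ring itself or its methyl goes with the higher number, a question that a plain phenyl group on the sulfonyl sulfur could settle. From the compounds shown here alone, how a chain ending in a carboxylic acid or an amine behaves at this position also remains open.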